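Dichlorobenzyl in Place of Benzyl on a Biphenyl Ether

The source may hold more compounds than are shown below. What is called first, only, known or untested is meant among the compounds shown, and "the series" means these compounds.

The three measured compounds share one core with two allyl chains and two aromatic oxygens. In a functional assay on MCF7 cells (Homo sapiens) for inhibition, read by MTT assay, with a stated time of 72 h (on this read-out higher numbers stand for weaker inhibition and lower numbers for stronger inhibition), compound 1 `C=CCc1ccc(OCc2ccc(Cl)cc2Cl)c(-c2ccc(OCc3ccc(Cl)cc3Cl)c(CC=C)c2)c1` reaches only the limit of > 50000 nM, so no number is known for it. Compound 2 `C=CCc1ccc(OCc2ccccc2)c(-c2ccc(OCc3ccccc3)c(CC=C)c2)c1` likewise stops at the limit of > 50000 nM in this assay. Among the measured compounds shown here, compound 3 `C=CCc1ccc(O)c(-c2ccc(OCc3ccccc3)c(CC=C)c2)c1` gives 23200 nM in this assay, the only number among the three. The other two values sit at the limit of > 50000 nM in this assay, at which 2 of the 3 values shown sit. For the measured compounds named here, the one measured step is an at least 2.1-fold lower number from compound 2 to compound 3 (0.33 log units; beyond the scatter), which swaps a whole benzyl for hydrogen on one oxygen.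

Compound 4 `C=CCc1ccc(O)c(-c2ccc(OCc3ccc(Cl)cc3Cl)c(CC=C)c2)c1` differs from compound 3 by 2,4-dichlorophenyl in place of phenyl on a saturated chain carbon bound to an oxygen on an aromatic ring. Going by the values given here, no measured step exchanges phenyl for 2,4-dichlorophenyl while the rest stays fixed. Compound 1 carries two dichlorobenzyl groups and compound 2 two plain benzyl groups, and since each only reached a limit, their values show no difference between the two groups. With nothing to point either way, the expected step is a 1.1-fold lower number from compound 3 to compound 4 (0.02 log units; within the scatter), no change beyond the scatter. Compound 4 is therefore estimated at 22000 nM in this assay, within a range from 8000 nM to 50000 nM.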

Compound 4, half-maximal inhibitory concentration: 14700 nM
Compound 4: middle estimate off by 1.5-fold (0.18 log units), on the high side; measured number inside the range.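

With a free hydroxyl on one oxygen, the change from benzyl to 2,4-dichlorobenzyl can now be read as a real number rather than against a limit: a 1.6-fold lower number from compound 3 to compound 4 (0.20 log units; within the scatter) in this assay. So on this oxygen, with the rest of the molecule fixed, the two chlorine atoms give no difference that this assay can separate from repeat-to-repeat variation. The dichlorobenzyl compounds also now have their own step for replacing one whole group with hydrogen, an at least 3.4-fold lower number from compound 1 to compound 4 (0.53 log units; beyond the scatter), which points the same way as an at least 2.1-fold lower number from compound 2 to compound 3 (0.33 log units; beyond the scatter), so in both pairs shown the compound with one free hydroxyl gives the lower number, and the doubly substituted compounds could not show the effect of the chlorines because they both stop at a limit: the limit of > 50000 nM in this assay, at which 2 of the 4 values shown sit.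

Still open, on these data alone, is whether anything on this oxygen would move the number beyond the scatter, for instance a methyl in place of the benzyl, or a carboxylic acid or an amine on the phenyl. The compounds shown also leave open how much the remaining group matters at all, since every measured number here still carries a benzyl or dichlorobenzyl on one oxygen.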